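Lengthening the amine chain on compound 3

The compounds below may be only part of what the source reports. "The series", "measured", "known", "first", "only" and "open" are said of these compounds alone.

Three compounds share one core and differ only in the group attached to the carbonyl carbon at the end of the side chain. Compound 1 `CC(C)(C)c1ccc(C(=O)N2CCC3(CC2)C(=O)N(CC(=O)NCCC(=O)O)CN3c2ccccc2)cc1` gives 11400 nM in an assay on HEK293 cells for displacement of a labelled ligand from NPC1-like intracellular cholesterol transporter 1 (Homo sapiens); a higher number here means a weaker inhibitor, a lower number a stronger inhibitor. Compound 2 `CC(C)(C)c1ccc(C(=O)N2CCC3(CC2)C(=O)N(CC(=O)N2CCCCC2CCO)CN3c2ccccc2)cc1` gives 6100 nM, and compound 3 `CC(C)(C)c1ccc(C(=O)N2CCC3(CC2)C(=O)N(CC(=O)NCCN)CN3c2ccccc2)cc1` gives 7000 nM. The steps among them are all small: a 1.9-fold lower number from compound 1 to compound 2 (0.27 log units; within the scatter), a 1.6-fold lower number from compound 1 to compound 3 (0.21 log units; within the scatter) and a 1.1-fold higher number from compound 2 to compound 3 (0.06 log units; within the scatter). Compound 3 thus stands second highest of the three numbers, with compound 2 nearest and compound 1 furthest, every gap within the scatter.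

Compound 4 `CC(C)(C)c1ccc(C(=O)N2CCC3(CC2)C(=O)N(CC(=O)NCCCN)CN3c2ccccc2)cc1` is the next step: aminomethyl in place of amino on a saturated chain carbon, two bonds along the chain from an amide-type nitrogen. In plain words, aminomethyl in place of amino on a saturated chain carbon, two bonds along the chain from an amide-type nitrogen. Among the measured compounds shown here, no measured step tests this exact change. The nearest comparisons, the exchange of carboxy for amino in a 1.6-fold lower number from compound 1 to compound 3 (0.21 log units; within the scatter) and the larger reshaping of the end group in a 1.1-fold higher number from compound 2 to compound 3 (0.06 log units; within the scatter), both stayed within the scatter. The expected step is therefore none beyond the scatter: no change at the digits printed from compound 3 to compound 4 (within the scatter). For compound 4 in this assay, the estimate is 7000 nM, with a range from 3500 nM to 14000 nM.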

Compound 4, half-maximal inhibitory concentration: 4200 nM
Estimate against measurement, compound 4: 1.7-fold (0.22 log units) above; measured number inside the range.
By their numbers in this assay, from the lowest: compounds 4, 2, 3 and 1 (each within the scatter of the next, the first and the last beyond it).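

In this assay, the change from (2-aminoethyl)amino to (3-aminopropyl)amino gives a 1.7-fold lower number from compound 3 to compound 4 (0.22 log units; within the scatter) and so adds one carbon to the chain without a shift that can be told from the scatter, which means this position accepts the longer amine chain. Replacing the whole 2-(2-hydroxyethyl)piperidin-1-yl end group gives a 1.5-fold lower number from compound 2 to compound 4 (0.16 log units; within the scatter) and likewise leaves no readable difference, so the amine with the longer chain and that quite different end group cannot be told apart here. Among the compounds shown here, the new information lies in a 2.7-fold lower number from compound 1 to compound 4 (0.43 log units; beyond the scatter) as the first step in this small set to pass beyond the scatter, though it is modest, and it separates the carboxylic acid from the longer amine, whereas the shorter amine of compound 3 stayed within the scatter of compound 1.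

Nothing shown here explains why the numbers fall as they do. Still open, from the compounds shown here alone, is whether a further carbon, as in a 4-aminobutyl chain, would carry the number lower, and whether a dimethylamino group at the chain end would serve as well as the plain amine.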